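Methyl to Ethyl on a Sodium/Hydrogen Exchanger Inhibitor Core

A few compounds are considered here, and "the series" means these few. Any claim that something is new, unique, unknown or untested is made for them only; others in the source may bear on it.

Compound 1 `Cc1cc(Cl)c(S(C)(=O)=O)cc1C(=O)N=C(N)N` carries a methyl group and a chloro group on its aromatic ring. In a functional assay for inhibition of sodium/hydrogen exchanger (Oryctolagus cuniculus) (a higher number here means a weaker inhibitor, a lower number a stronger inhibitor), compound 1 gives 25 nM. Compound 2 `CCc1cc(Cl)c(S(C)(=O)=O)cc1C(=O)N=C(N)N` differs from compound 1 by methyl in place of hydrogen on a saturated chain carbon bound to an aromatic carbon, and compound 2 gives 63 nM, so a 2.5-fold higher number from compound 1 to compound 2 (0.40 log units; beyond the scatter). Compound 3 `Cc1cc(C)c(S(C)(=O)=O)cc1C(=O)N=C(N)N` differs from compound 1 by methyl in place of chloro on an aromatic carbon; in this assay compound 3 gives 11 nM, which makes a 2.3-fold lower number from compound 1 to compound 3 (0.36 log units; beyond the scatter). Compound 4 `CCc1cc(C)c(C(=O)N=C(N)N)cc1S(C)(=O)=O` has not yet been measured and differs from compound 3 by methyl in place of hydrogen on a saturated chain carbon bound to an aromatic carbon. This is the same change, at the same place, as the one from compound 1 to compound 2, and it occurs twice among these four compounds. Resting on a 2.5-fold higher number from compound 1 to compound 2 (0.40 log units; beyond the scatter), which came from this very change, the step for compound 4 is expected to be a 2.5-fold higher number from compound 3 to compound 4 (0.41 log units; beyond the scatter). Compound 4 is therefore estimated at 28 nM, with a likely range from 14 nM to 60 nM.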

Compound 4, half-maximal inhibitory concentration: 4.8 nM
Estimate against measurement, compound 4: 5.8-fold (0.77 log units) above; the whole stated range lies above it.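

On the core of compound 3, methyl to ethyl gives a 2.3-fold lower number from compound 3 to compound 4 (0.36 log units; beyond the scatter), so in this assay the same change moves the number in opposite directions on the two cores: the same change on two cores in this assay, a 2.5-fold higher number (0.40 log units; beyond the scatter) from compound 1 to compound 2 and a 2.3-fold lower number (0.36 log units; beyond the scatter) from compound 3 to compound 4, 5.8-fold (0.76 log units) apart, beyond the scatter of two such steps Ethyl in place of chloro gives a 5.2-fold lower number from compound 1 to compound 4 (0.72 log units; beyond the scatter), the largest step to compound 4 shown here. This shows that a step read on one core cannot simply be added onto another in this series, but it does not show why the two cores part, and two pairs of compounds set no rule for other cores. On these data alone, whether a longer chain such as propyl would follow the direction of the first pair or the second stays open. So does the effect of an amine at that carbon.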